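Cytotoxicity notes: aryl change on the isoxazole, compound 3 to compound 4

The compounds below may be only part of what the source reports. "The series", "measured", "known", "first", "only" and "open" are said of these compounds alone.

Measured compounds in an ADME assay on cells (Fibroblast, Homo sapiens) for cytotoxicity, with a stated time of 48 h; on this read-out higher numbers stand for weaker inhibition and lower numbers for stronger inhibition:
- compound 1 `O=[N+]([O-])c1ccc(CN2CCC(n3cc(CC(OCc4cc(-c5ccccc5)no4)c4ccc(Br)cc4)nn3)CC2)cc1`: compound 1 gives > 25000 nM, a limit of the assay.
- compound 2 `COc1ccc(-c2cc(COC(Cc3cn(C4CCN(Cc5ccc([N+](=O)[O-])cc5)CC4)nn3)c3ccc(Br)cc3)on2)cc1`: compound 2 gives > 25000 nM, a limit of the assay.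
- compound 3 `O=[N+]([O-])c1ccc(CN2CCC(n3cc(CC(OCc4cc(-c5cccc(Br)c5)no4)c4ccc(Br)cc4)nn3)CC2)cc1`: compound 3 gives > 25000 nM, a limit of the assay.

Compound 3 stands only at a limit in this assay, and the two other values shown are limits as well (the limit of > 25000 nM in this assay, at which 3 of the 3 values shown sit). Compound 4 `COc1ccccc1-c1cc(COC(Cc2cn(C3CCN(Cc4ccc([N+](=O)[O-])cc4)CC3)nn2)c2ccc(Br)cc2)on1` is not yet measured. Its difference from compound 3 is 2-methoxyphenyl in place of 3-bromophenyl on an aromatic carbon.

The steps that reach compound 3 are a step that the two limits leave unreadable from compound 1 to compound 3 and a step that the two limits leave unreadable from compound 2 to compound 3; neither can be read in size, since both ends sit at the limit. The step between compound 1 and compound 2, a step that the two limits leave unreadable from compound 1 to compound 2, is likewise unreadable. Nothing in these numbers separates the aryl groups on the shared core in this assay. For compound 4 the step that the limit leaves unreadable from compound 3 to compound 4 is therefore expected to stay unreadable, with the value again at the limit. The estimate for compound 4 is 40000 nM, within 15000 nM to 150000 nM.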

Compound 4, half-maximal inhibitory concentration: > 25000 nM
Compound 4: no number, only a limit; the forecaster's own chance of this, stated with the estimate: 85%; the middle value is on the limit's open side.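

The steps from compound 1, compound 2 and compound 3 to compound 4 cannot be read in size, with both ends of each step at a limit: the limit of > 25000 nM in this assay, at which 4 of the 4 values shown sit.

The compounds shown leave open whether the aryl groups on the shared core differ at all in this assay.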